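From cyclopropyl to propyl on a carbonyl carbon

A few compounds are considered here, and "the series" means these few. Any claim that something is new, unique, unknown or untested is made for them only; others in the source may bear on it.

Compound 1 `CCC(=O)NCc1ccc(C(=O)Nc2ccc(C)c(Nc3nccc(-c4cccnc4)n3)c2)cc1`: > 10000 nM
Compound 2 `Cc1ccc(NC(=O)c2ccc(CN(CCN(C)C)C(=O)C3CC3)cc2)cc1Nc1nccc(-c2cccnc2)n1`: > 10000 nM

In an ADME assay on BaF3 cells (Mus musculus) for cytotoxicity, read by CellTiter-Glo and CCK-8 assay, with a stated time of 72 h (on this read-out lower numbers stand for stronger inhibition of growth and higher numbers for weaker inhibition of growth), compound 1 gives > 10000 nM, which is a limit of the assay and not a number. Compound 2 gives > 10000 nM, also only a limit. So compound 2 stands at the limit of > 10000 nM in this assay, at which 2 of the 2 values shown sit.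

Compound 3 `CCCC(=O)N(CCN(C)C)Cc1ccc(C(=O)Nc2ccc(C)c(Nc3nccc(-c4cccnc4)n3)c2)cc1` has propyl in place of cyclopropyl on a carbonyl carbon.

Within the data shown here, the only measured change is a step that the two limits leave unreadable from compound 1 to compound 2, so it offers no size to carry over, and no shift beyond the scatter is expected. The expected change is a step that the limit leaves unreadable from compound 2 to compound 3. For compound 3 the estimate is 12000 nM, with an expected range from 5000 nM to 30000 nM.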

Compound 3, concentration for 50% growth inhibition: > 10000 nM
Compound 3 was reported as a limit; the forecaster's own chance of this, stated with the estimate: 80%; the middle value is on the limit's open side.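

Among these compounds, compound 3 gives > 10000 nM, a limit of the assay and not a number, so no step involving compound 1, compound 2 or compound 3 can be read. Left open is how strongly any of these compounds inhibits growth in this assay, and whether cyclopropyl and propyl differ there at all.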